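Chloro in Place of Fluoro: Compound 3 to Compound 4

A few compounds are considered here, and "the series" means these few. Any claim that something is new, unique, unknown or untested is made for them only; others in the source may bear on it.

Of the compounds shown here, three sharing one core have been measured in an in vitro assay on BTI-TN-5B1-4 cells for inhibition of Amine oxidase [flavin-containing] A (Homo sapiens), read by fluorescence, with a stated time of 15 min, tested at 100 uM; a higher number here means more inhibition at the concentration tested (going by the name of the read-out), a lower number less inhibition. Compound 1 `Clc1ccc(-c2csc(N/N=C/c3ccccc3)n2)cc1` gives 40% in this assay. Compound 2 `Clc1ccc(/C=N/Nc2nc(-c3ccc(Cl)cc3)cs2)cc1` gives 40% in this assay. Among the measured compounds shown here, the single step joining two measured compounds runs no change at the digits printed from compound 1 to compound 2 (within the scatter), a chloro in place of hydrogen on an aromatic carbon that left the read-out where it was. Compound 3 `Cc1ccccc1/C=N/Nc1nc(-c2ccc(F)cc2)cs1` gives 40% in this assay, so it stands level with compound 1 and with compound 2 at the digits shown; the two values in each pair are the same.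

Compound 4 `Cc1ccccc1/C=N/Nc1nc(-c2ccc(Cl)cc2)cs1` differs from compound 3 by chloro in place of fluoro on an aromatic carbon. For the measured compounds named here, the one measured step, from compound 1 to compound 2, also introduced a chloro on an aromatic carbon of the same kind of ring and produced no change beyond the scatter; it is the closest guide available, though there hydrogen rather than fluoro left. The expected step is therefore no change at the digits printed from compound 3 to compound 4 (within the scatter), nothing beyond the scatter in either direction. Compound 4 is thus estimated to give 40% in this assay, with an expected range from 28% to 52%.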

Compound 4, a percentage reported as inhibition, at one concentration (the size of the read-out at that concentration, not a potency): 40%
Estimate against measurement, compound 4: no gap at the digits printed, within the range that was stated.
By their numbers in this assay, from the lowest: compounds 1, 2, 3 and 4 (each within the scatter of the next).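

In this assay, the change from 4-fluorophenyl to 4-chlorophenyl runs no change at the digits printed from compound 3 to compound 4 (within the scatter), so chloro leaves the read-out in place whether it enters for hydrogen or for fluoro. The two further links agree: 2-methylphenyl in place of 4-chlorophenyl on a carbon with a double bond to nitrogen runs no change at the digits printed from compound 2 to compound 4 (within the scatter), and the methyl that compound 4 carries where compound 1 has a hydrogen runs no change at the digits printed from compound 1 to compound 4 (within the scatter), so no single change shown here moves the read-out beyond the scatter. No evidence is available that bears on this flat result.

The compounds shown leave open whether an amine or a carboxylic acid on that aromatic carbon would shift the reading. Level readings at one concentration also leave open whether these compounds would stay level at other concentrations.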